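The source may hold more compounds than are shown below. What is called first, only, known or untested is meant among the compounds shown, and "the series" means these compounds.

In a functional assay on MCF7 cells (Homo sapiens) for cytotoxicity, read by MTT assay, with a stated time of 72 h (a higher number here means a weaker inhibitor, a lower number a stronger inhibitor), measured so far:
Compound 1 `Cc1ccc(-c2cc(/N=C3/NC(=O)CS3)cs2)cc1`: > 50000 nM (a limit, not a number)
Compound 2 `O=C1CS/C(=N\c2csc(-c3ccc(Cl)cc3)c2)N1`: > 50000 nM (a limit, not a number)

Compound 2 stands only as a limit, with no number to start from. Both measured compounds share the same reading: the limit of > 50000 nM in this assay, at which 2 of the 2 values shown sit. Within the data shown here, the single measured step is a step that the two limits leave unreadable from compound 1 to compound 2, and it offers no size to carry forward.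

Compound 3 `O=C1CS/C(=N\c2csc(-c3ccc(Cl)cc3)c2)N1c1ccc(Cl)cc1` carries 4-chlorophenyl in place of hydrogen on an amide-type nitrogen in a ring. Among the measured compounds shown here, no measured step touches that nitrogen, and the expectation starts from the limit of compound 2. In this assay a modest move towards a stronger inhibitor is expected, though with low confidence, and a further reading at the limit remains quite possible. The estimated step is an at least 1.6-fold lower number from compound 2 to compound 3 (0.22 log units; that floor lies within the scatter). Compound 3 is expected at about 30000 nM, with an estimated range of 8000 nM to 80000 nM.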

Compound 3, half-maximal inhibitory concentration: > 50000 nM
Compound 3: only a limit was reported (the forecaster's own chance of this, stated with the estimate: 45%); at least 1.6-fold (0.22 log units) between middle value and limit.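

The step from compound 2 to compound 3 cannot be read in this assay, since both readings are limits and not numbers: the limit of > 50000 nM in this assay, at which 3 of the 3 values shown sit.

The compounds shown leave open whether any change on the shared core gives a number rather than a limit in this assay.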